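A few compounds are considered here, and "the series" means these few. Any claim that something is new, unique, unknown or untested is made for them only; others in the source may bear on it.

Measured so far in an ADME assay on microsomes from liver (Rattus norvegicus) for metabolic stability; on this read-out lower numbers stand for a shorter-lived compound and higher numbers for a longer-lived compound:
- compound 1 `CC(C)C(Cc1ncc[nH]1)c1ccc(-c2ccc3cccc(F)c3c2)[nH]c1=O`: < 0.0667 h, a limit
- compound 2 `CC(C)C(CC(N)=O)c1ccc(-c2ccc3cccc(F)c3c2)[nH]c1=O`: < 0.0667 h, a limit

Compound 2 has no numerical half-life, only the limit < 0.0667 h. Within the data shown here, the series so far gives (the limit of < 0.0667 h in this assay, at which 2 of the 2 values shown sit). Among the measured compounds shown here, the one measured step is a step that the two limits leave unreadable from compound 1 to compound 2, so it offers no size to carry forward.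

Compound 3 `CC(C)C(/C=C1\CCNC1=O)c1ccc(-c2ccc3cccc(F)c3c2)[nH]c1=O` keeps the shared core and changes the same side chain. The difference is a group of 7 heavy atoms (5 carbon, 1 nitrogen, 1 oxygen; one five-membered non-aromatic ring with 1 hetero atom) in place of a group of 4 heavy atoms (2 carbon, 1 nitrogen, 1 oxygen; no ring), on a saturated chain carbon bound to an aromatic carbon and a saturated chain carbon. The new group stands on a saturated chain carbon bound to an aromatic carbon and a saturated chain carbon. For the measured compounds named here, no measured step covers this change, and the data give no direction for it.

The expectation of a short half-life for compound 3 rests on compound 2 with its limit < 0.0667 h. No step beyond the scatter is expected in this assay, and a report at the limit is the likeliest result. The expected step is a step that the limit leaves unreadable from compound 2 to compound 3. For compound 3 the estimated half-life is 0.05 h, with an expected range of 0.02 h to 0.15 h.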

Compound 3, half-life: 0.345 h
Compound 3: middle estimate off by 6.9-fold (0.84 log units), on the low side, outside the stated range (above it).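

In this assay, this side chain, on a saturated chain carbon bound to an aromatic carbon and a saturated chain carbon, now proves able to carry a change with a readable effect: the group holding the five-membered non-aromatic ring, in place of carbamoylmethyl, gives an at least 5.1-fold higher number from compound 2 to compound 3 (0.71 log units; beyond the scatter). The same group, in place of the group holding the five-membered aromatic ring, gives an at least 5.1-fold higher number from compound 1 to compound 3 (0.71 log units; beyond the scatter); both steps are beyond the scatter and point the same way, whereas the step between the two earlier compounds cannot be read. Compound 3 is the only compound shown with a numerical half-life, and both steps give only a minimum size, with the full distance from the other two compounds unknown: the limit of < 0.0667 h in this assay, at which 2 of the 3 values shown sit.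

The entering group differs from carbamoylmethyl in its ring, its size and its count of double bonds outside aromatic rings all at once, and the compounds shown do not separate these features. As far as these compounds go, it also remains open whether a plain amine, a carboxylic acid or a longer saturated carbon chain on this carbon would give a half-life that can be read in this assay.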